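Aryl swap on the pyrazole nitrogen of compound 3

The source may report more compounds than this note shows. Statements on the series, on what has been measured and on what is new or still open speak of the compounds shown alone.

Measured compounds:
- compound 1, `Cn1ncc2cc(NC(=O)NCc3cc(C(F)(F)F)nn3-c3cccc(Cl)c3)ccc21`: 61 nM
- compound 2, `CC(C)(C)c1cc(CNC(=O)Nc2cccc3[nH]ncc23)n(-c2cccc(Cl)c2)n1`: 0.6 nM
- compound 3, `Cn1ncc2c(NC(=O)NCc3cc(C(F)(F)F)nn3-c3cccc(F)c3)cccc21`: 7 nM

In an assay on CHO-K1 cells for antagonist activity at transient receptor potential cation channel subfamily V member 1 (Homo sapiens), read by FLIPR and calcium flux, with a stated time of 6 min (a lower number here means a stronger inhibitor, a higher number a weaker inhibitor), compound 3 gives 7 nM and stands second highest of the three numbers. Its nearest neighbour is compound 1, which gives 61 nM in this assay, a number well beyond the scatter above it. Furthest away is compound 2, which gives 0.6 nM, beyond the scatter below it. Among the measured compounds shown here, neither neighbour differs from compound 3 in one place only, so no single step between measured compounds is available.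

Compound 4, `Cc1ccc(-n2nc(C(F)(F)F)cc2CNC(=O)Nc2cccc3c2cnn3C)cc1C`, follows from compound 3 by one change: 3,4-dimethylphenyl in place of 3-fluorophenyl on an aromatic nitrogen. For the measured compounds named here, no measured pair shows the effect of this exchange, so the expectation rests on the spread seen across compounds 1 to 3 alone. The step from compound 3 to compound 4 is expected to be small, a 1.4-fold higher number from compound 3 to compound 4 (0.15 log units; within the scatter), most likely not beyond the scatter, with a modest rise in the number considered the more probable direction if any appears. Compound 4 is accordingly estimated at 10 nM in this assay, in the range 2.5 nM to 40 nM.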

Compound 4, inhibition constant: 3.5 nM
For compound 4 the middle estimate is 2.9-fold (0.46 log units) above the measured one, and the stated range covers the measured number.
By their numbers in this assay, from the lowest: compound 2; then compounds 4 and 3 (each within the scatter of the next); then compound 1.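

In this assay, among the compounds shown here, 3,4-dimethylphenyl in place of 3-fluorophenyl on the aromatic nitrogen gives a 2.0-fold lower number from compound 3 to compound 4 (0.30 log units; within the scatter), the first step that isolates a single place. This aromatic nitrogen therefore accepts an aryl group without fluorine and with a larger substitution pattern, with no change beyond the scatter, which compounds 1 to 3 could not show. No measured property bears on this result, so the step remains a plain observation.

This single exchange removes the fluorine and adds both methyl groups at once, so 3-methylphenyl or 4-methylphenyl would be needed to separate their contributions. On these data alone, whether this position also accepts an aryl group carrying an amine or a carboxylic acid, or a pyridine ring in place of the phenyl, remains open.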